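The compounds below may be only part of what the source reports. "The series", "measured", "known", "first", "only" and "open" are said of these compounds alone.

Measured so far:
- compound 1 `COc1cccc(CNCCCNc2ccnc3cc(Cc4ccc(F)cc4)ccc23)c1O`: 4780 nM
- compound 2 `CCC(CC)c1ccc2c(NCCCNCc3ccco3)ccnc2c1`: 6760 nM
- compound 3 `COc1ccccc1Oc1ccc2c(NCCCNCc3ccco3)ccnc2c1`: 6500 nM

All three numbers come from an ADME assay on HepG2 cells (Homo sapiens) for cytotoxicity, read by luminescence, CellTiter-Glo and ATP content, with a stated time of 72 h; on this read-out higher numbers stand for an effect only at larger amounts of compound and lower numbers for an effect already at smaller amounts. The three values lie within the scatter of one another, so compound 3 cannot be set apart from compound 1 or compound 2 on these data. Among the measured compounds shown here, the only single-point step recorded is a 1.0-fold lower number from compound 2 to compound 3 (0.02 log units; within the scatter), which concerns the aromatic carbon of the core and not the amine end.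

Compound 4 `COc1ccccc1Oc1ccc2c(NCCCNCc3cccc(OC)c3O)ccnc2c1` differs from compound 3 by 2-hydroxy-3-methoxyphenyl in place of furan-2-yl on a saturated chain carbon bound to an amine nitrogen. For the measured compounds named here, no measured step touches this position directly. Compound 1 already carries the 2-hydroxy-3-methoxybenzyl amine, and its value and that of compound 3 sit within the scatter of each other. The step of a 1.2-fold lower number from compound 3 to compound 4 (0.07 log units; within the scatter) is therefore expected to stay within the scatter. Compound 4 is estimated at 5500 nM, range 2500 nM to 12000 nM.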

Compound 4, half-maximal effective concentration: 11200 nM
For compound 4 the middle estimate is 2.0-fold (0.31 log units) below the measured one; low and high end bracket the measured number.
By their numbers in this assay, from the lowest: compounds 1, 3, 2 and 4 (each within the scatter of the next, the first and the last beyond it).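

In this assay the change to 2-hydroxy-3-methoxyphenyl in place of furan-2-yl on a saturated chain carbon bound to an amine nitrogen gives a 1.7-fold higher number from compound 3 to compound 4 (0.24 log units; within the scatter), so this position shows no change that can be told from scatter. Among the compounds shown here, with that group held, 2-methoxyphenoxy in place of 4-fluorobenzyl on an aromatic carbon gives a 2.3-fold higher number from compound 1 to compound 4 (0.37 log units; beyond the scatter), the first modest step. The data offer no explanation for either step. Going by these compounds, whether a carboxylic acid or a dimethylamino group on that saturated chain carbon would give a step beyond the scatter stays open.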